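The compounds below may be only part of what the source reports. "The series", "measured", "known", "first", "only" and "open" are said of these compounds alone.

Of the compounds shown here, three have been measured in an assay on isolated protein for inhibition of cathepsin S (Homo sapiens); on this read-out higher numbers stand for weaker inhibition and lower numbers for stronger inhibition. Compound 1 `CC1CCC(C[C@H](CC(=O)N2CCOCC2)C(=O)N[C@]2(C#N)CCN(C3CCCCC3)C2)CC1` gives 14 nM; compound 2 `N#C[C@@]1(NC(=O)[C@@H](CC(=O)N2CCOCC2)CC2CCCCC2)CCN(C2CCCC2)C1` gives 75 nM; compound 3 `N#C[C@@]1(NC(=O)[C@@H](CC(=O)N2CCOCC2)CC2Cc3ccccc3C2)CCN(C2CCCCC2)C1` gives 42 nM, the second highest of the three numbers, within the scatter of compound 2 and beyond it from compound 1. Going by the values given here, the one measured step in this region, a 3.0-fold higher number from compound 1 to compound 3 (0.48 log units; beyond the scatter), is the only step that bears on the change to compound 4 `N#C[C@@]1(NC(=O)[C@@H](CC(=O)N2CCOCC2)CC2CCCCC2)CCN(C2CCCCC2)C1`, which is cyclohexyl in place of 2,3-dihydro-1H-inden-2-yl on a saturated chain carbon, two bonds along the chain from a carbonyl carbon. Compound 1 with 4-methylcyclohexyl sits below compound 3, and compound 2 carries cyclohexyl at the same place with a cyclopentyl on the ring nitrogen instead. A move in the opposite direction to that measured step is expected. In this assay the expected step is roughly a 2.1-fold lower number from compound 3 to compound 4 (0.32 log units; beyond the scatter). Compound 4 is therefore estimated at 20 nM, with a range from 8 nM to 50 nM.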

Compound 4, half-maximal inhibitory concentration: 23 nM
Compound 4: the middle estimate sits 1.2-fold (0.06 log units) below what was measured; the measured number falls inside the stated range.
By their numbers in this assay, from the lowest: compounds 1, 4, 3 and 2 (each within the scatter of the next, the first and the last beyond it).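

In this assay, cyclohexyl in place of 2,3-dihydro-1H-inden-2-yl on a saturated chain carbon, two bonds along the chain from a carbonyl carbon, stays within the scatter (a 1.8-fold lower number from compound 3 to compound 4 (0.26 log units; within the scatter)), as does hydrogen in place of methyl on a saturated ring carbon (a 1.6-fold higher number from compound 1 to compound 4 (0.22 log units; within the scatter)). Cyclohexyl in place of cyclopentyl on an amine nitrogen in a ring goes beyond the scatter (a 3.3-fold lower number from compound 2 to compound 4 (0.51 log units; beyond the scatter)), giving the first reading of a change at that nitrogen. No measured evidence accounts for these steps. The compounds shown leave open how an open-chain isopropyl group on that nitrogen would read, and how a phenyl group on the saturated chain carbon would compare.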